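This account rests on a few compounds, and the source may have more. Where it says the series, first, only, none or still open, it means among the compounds named here.

Of the compounds shown here, two that share one core have been measured in a functional assay on DU-145 cells (Homo sapiens) for cytotoxicity, read by MTT assay, with a stated time of 2 days; on this read-out higher numbers stand for weaker inhibition and lower numbers for stronger inhibition. Compound 1 `CCCCCNc1nc(NCc2ccco2)c2cc(F)ccc2n1` carries a pentyl chain on a nitrogen on an aromatic ring; in this assay compound 1 gives 7240 nM. Compound 2 `COc1ccc(Nc2nc(NCc3ccco3)c3cc(F)ccc3n2)cc1` carries a 4-methoxyphenyl at that same nitrogen; in this assay compound 2 gives 11600 nM. For the measured compounds named here, the single step between them, a 1.6-fold higher number from compound 1 to compound 2 (0.20 log units; within the scatter), lies within the scatter, so although compound 2 holds the higher of the two numbers, the two compounds cannot be told apart on what has been measured.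

Compound 3 `CCCCNc1nc(NCc2ccco2)c2cc(F)ccc2n1` has not yet been measured. It differs from compound 2 in one place: butyl in place of 4-methoxyphenyl on a nitrogen on an aromatic ring. Going by the values given here, the only step that bears on this change is the one that swapped a plain chain for the 4-methoxyphenyl, which was a 1.6-fold higher number from compound 1 to compound 2 (0.20 log units; within the scatter) and stayed within the scatter. A butyl chain is close in kind to the pentyl of compound 1, so the reverse swap is not expected to move the number beyond the scatter either. The step of a 1.5-fold lower number from compound 2 to compound 3 (0.16 log units; within the scatter) is therefore expected to be small. In this assay compound 3 is estimated at 8000 nM, with a likely range from 3500 nM to 18000 nM.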

Compound 3, half-maximal inhibitory concentration: 5910 nM
Compound 3: middle estimate off by 1.4-fold (0.13 log units), on the high side; low and high end bracket the measured number.
By their numbers in this assay, from the lowest: compounds 3, 1 and 2 (each within the scatter of the next).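

At the nitrogen on an aromatic ring, butyl replaces the 4-methoxyphenyl in this assay and removes the six-membered aromatic ring and the hydrogen-bond acceptor, yet this larger change in structure gives a 2.0-fold lower number from compound 2 to compound 3 (0.29 log units; within the scatter) and so cannot be told from repeat-measurement noise. Trimming the chain itself, with hydrogen in place of methyl on the saturated chain carbon four bonds along from that nitrogen, gives a 1.2-fold lower number from compound 1 to compound 3 (0.09 log units; within the scatter) and likewise stays within the scatter. Across these three compounds, neither the chain length tested nor the swap between a chain and a substituted aromatic ring separates the numbers, and no supporting evidence offers an explanation for this.

On these data alone, what remains open is whether a group of a different kind at this nitrogen, such as a much longer chain like dodecyl, a chain ending in an amine or one ending in a carboxylic acid, would move the number beyond the scatter. All three compounds also share the rest of the core, so the effect of changes elsewhere on the molecule cannot be judged from them.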